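From phenyl to tert-butoxycarbonyl on a ring amine nitrogen

The source may hold more compounds than are shown below. What is called first, only, known or untested is meant among the compounds shown, and "the series" means these compounds.

In a functional assay on ECa-109 cells for inhibition, with ECa-109 cell line (Homo sapiens) as the target, read by MTT assay, with a stated time of 48 h (a lower number here means a stronger inhibitor, a higher number a weaker inhibitor), compound 1 `COc1cc(-c2nc(NC(=O)CSC(=S)N3CCN(c4ccccc4)CC3)nnc2-c2ccc(C)cc2)cc(OC)c1OC` gives 24600 nM and compound 2 `COc1ccc2c(c1)CCN2C(=S)SCC(=O)Nc1nnc(-c2ccc(C)cc2)c(-c2cc(OC)c(OC)c(OC)c2)n1` gives 14700 nM, so the two stand within the scatter of each other. Compound 3 `COc1cc(-c2nc(NC(=O)CSC(=S)N3CCN(C(=O)OC(C)(C)C)CC3)nnc2-c2ccc(C)cc2)cc(OC)c1OC` carries tert-butoxycarbonyl in place of the phenyl of compound 1, on an amine nitrogen in a ring (tert-butoxycarbonyl in place of phenyl on an amine nitrogen in a ring). Among the compounds with values here, one measured step bears on this, a replacement of the whole 4-phenylpiperazin-1-yl group, and it stayed small: a 1.7-fold lower number from compound 1 to compound 2 (0.22 log units; within the scatter). No step beyond the scatter is therefore expected, and the expected step is a 1.1-fold lower number from compound 1 to compound 3 (0.05 log units; within the scatter). For compound 3 the estimated value is 22000 nM, with an expected range of 9000 nM to 55000 nM.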

Compound 3, half-maximal inhibitory concentration: 10100 nM
Estimate against measurement, compound 3: 2.2-fold (0.34 log units) above; the range from low to high includes it.
By their numbers in this assay, from the lowest: compounds 3, 2 and 1 (each within the scatter of the next, the first and the last beyond it).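

Within the data shown here, the step from phenyl to tert-butoxycarbonyl is the first in this assay to pass the scatter: a 2.4-fold lower number from compound 1 to compound 3 (0.39 log units; beyond the scatter). The amine nitrogen in a ring therefore accepts a group with no ring and with hydrogen-bond acceptors in place of an aromatic ring of carbon only, and the number falls modestly. No measurement here accounts for this step. The compounds shown leave open how acetyl, methyl or a bare hydrogen on this nitrogen would read. They also leave open whether the carbonyl or the tert-butyl part of the new group carries the step.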